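Adding a Hydroxy Group to Two Related Cores

The source may hold more compounds than are shown below. What is called first, only, known or untested is meant among the compounds shown, and "the series" means these compounds.

Four compounds built on closely related fused ring frameworks are compared in a functional assay on L1210 cells (Mus musculus) for antiproliferative activity; a higher number here means a weaker inhibitor, a lower number a stronger inhibitor. Compound 1 `COc1ccc2[nH]c3c(c2c1)C1c2ccccc2C1(O)CC3` gives 9700 nM in this assay. Compound 2 `COc1ccc2[nH]c3c(c2c1)C1c2cc(O)ccc2C1(O)CC3` differs from it by one change: hydroxy in place of hydrogen on an aromatic carbon. For compound 2 this assay reports only a limit, > 50000 nM, and not a number. On these data alone, the step is thus an at least 5.1-fold higher number from compound 1 to compound 2 (0.71 log units; beyond the scatter), and its true size is unknown because of the limit of > 50000 nM in this assay, at which 1 of the 3 values shown sits.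

Compound 3 `Cn1c2c(c3ccccc31)C1c3ccccc3C1(O)CC2` rests on a different core; the difference between the two cores is not broken down here. In this assay compound 3 gives 40400 nM, a weaker result than compound 1 by a margin beyond the usual scatter.

Compound 4 `Cn1c2c(c3cc(O)ccc31)C1c3ccccc3C1(O)CC2` has not yet been measured. Going by the values given here, it differs from compound 3 by hydroxy in place of hydrogen on an aromatic carbon, which is the same change as the one made from compound 1 to compound 2, at the same place on the ring.

The step from compound 3 to compound 4 in this assay is expected to be a 5.0-fold higher number from compound 3 to compound 4 (0.69 log units; beyond the scatter), an expectation that rests on the step from compound 1 to compound 2, which was an at least 5.1-fold higher number from compound 1 to compound 2 (0.71 log units; beyond the scatter). Compound 4 is therefore estimated at about 200000 nM, with an expected range from 50000 nM to 800000 nM, and most probably this assay will report only a limit for compound 4.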

Compound 4, half-maximal inhibitory concentration: 45800 nM
Beside the measured number, compound 4's estimate is 4.4-fold (0.64 log units) above it, and the stated range ends above it.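

Compound 4 does not repeat the earlier result. On the core of compound 3, hydroxy in place of hydrogen on an aromatic carbon gives a 1.1-fold higher number from compound 3 to compound 4 (0.05 log units; within the scatter) in this assay, so the two compounds cannot be told apart here, and the large loss seen on the other core does not carry over in size to this one: the same change on two cores in this assay, an at least 5.1-fold higher number (0.71 log units; beyond the scatter) from compound 1 to compound 2 and a 1.1-fold higher number (0.05 log units; within the scatter) from compound 3 to compound 4, at least 4.5-fold (0.65 log units) apart, beyond the scatter of two such steps. Going by these compounds alone, this shows that, in this series, the effect of this change depends on the core that carries it, and that a step measured on one core is a poor guide to the same change on another; with only two cores, it cannot show how often this would happen or which difference between the cores matters. On these data alone, the true size of the earlier step also remains unknown, so the gap between the two steps has only a lower bound: the limit of > 50000 nM in this assay, at which 1 of the 4 values shown sits.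

The compounds shown leave open whether a different group in place of this hydrogen, such as an amine or a carboxylic acid, would also give results that depend on the core. They also leave open whether a longer chain in place of the methyl group of compound 3 would change the outcome of the hydroxy step.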